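Small steps around the sulfonamide nitrogen group

The source may report more compounds than this note shows. Statements on the series, on what has been measured and on what is new or still open speak of the compounds shown alone.

Measured in a functional assay on HT-1080 cells (Homo sapiens) for antiproliferative activity, read by sulforhodamine B assay, with a stated time of 48 h (on this read-out lower numbers stand for stronger inhibition and higher numbers for weaker inhibition), so far:
Compound 1 `Cc1cccc(NS(=O)(=O)c2ccc(N3CCNC3=O)cc2)c1` gives 210 nM
Compound 2 `CCc1cccc(NS(=O)(=O)c2ccc(N3CCNC3=O)cc2)c1` gives 200 nM
Compound 3 `O=C1NCCN1c1ccc(S(=O)(=O)Nc2cccc(Br)c2)cc1` gives 170 nM

On these numbers, compound 3 cannot be separated from the other two compounds. Bromo in place of methyl gives a 1.2-fold lower number from compound 1 to compound 3 (0.09 log units; within the scatter) and bromo in place of ethyl gives a 1.2-fold lower number from compound 2 to compound 3 (0.07 log units; within the scatter) in the same test. Methyl in place of hydrogen on the saturated chain gives a 1.1-fold lower number from compound 1 to compound 2 (0.02 log units; within the scatter) as well.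

Compound 4 `Cc1cc(C)cc(NS(=O)(=O)c2ccc(N3CCNC3=O)cc2)c1` has not yet been measured. Relative to compound 3, it carries 3,5-dimethylphenyl in place of 3-bromophenyl on a sulfonamide nitrogen. All three measured steps bear on this change, since each swaps one group on the same aromatic part of the molecule, and each stayed small. Within the data shown here, no measured compound has the 3,5-dimethylphenyl group, however, so its effect remains untested and the range must stay wide.

From these steps, no change beyond the scatter and no clear direction is expected in this assay for this exchange. The estimated step is a 1.1-fold higher number from compound 3 to compound 4 (0.02 log units; within the scatter) on that reckoning. Compound 4 is estimated at 180 nM (expected range 70 nM to 450 nM).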

Compound 4, half-maximal inhibitory concentration: 150 nM
The estimate for compound 4 lay 1.2-fold (0.08 log units) above the measured number; low and high end bracket the measured number.
By their numbers in this assay, from the lowest: compounds 4, 3, 2 and 1 (each within the scatter of the next).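

In this assay, adding a second methyl on the aromatic ring gives a 1.4-fold lower number from compound 1 to compound 4 (0.15 log units; within the scatter), so the ring on the sulfonamide nitrogen can carry two methyl groups without a change that can be told from the scatter. Two further exchanges stay within the scatter as well: 3,5-dimethylphenyl in place of 3-bromophenyl gives a 1.1-fold lower number from compound 3 to compound 4 (0.05 log units; within the scatter), and 3,5-dimethylphenyl in place of 3-ethylphenyl gives a 1.3-fold lower number from compound 2 to compound 4 (0.12 log units; within the scatter). The four compounds therefore form a flat set at this position, whether the ring carries a single methyl, ethyl or bromo group or two methyl groups, and no measurement shown here offers an explanation for this flatness.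

The compounds shown leave open whether this flatness would survive a carboxylic acid, an amine or a methoxy group on the ring, or a saturated chain on the sulfonamide nitrogen in place of the aromatic ring. They also leave open whether the same small steps would appear on cells other than HT-1080.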